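The source may report more compounds than this note shows. Statements on the series, on what has been measured and on what is new or still open speak of the compounds shown alone.

Measured so far in an ADME assay on Huh-7 cells (Homo sapiens) for cytotoxicity; a lower number here means that less compound is tolerated, a higher number that more compound is tolerated:

compound 1 `Cc1ccccc1-c1nn(-c2ccc(Cl)cc2)cc1CNCCN1CCN(C)CC1`: 17000 nM
compound 2 `Cc1ccccc1CNc1nn(-c2ccc(F)cc2F)cc1CNCCN1CCN(C)CC1`: > 20000 nM, a limit of this assay
compound 3 `CN1CCN(CCNCc2cn(-c3ccc(F)cc3F)nc2Cc2ccccc2)CC1`: > 20000 nM, a limit of this assay

Among the measured compounds shown here, compound 1 gives the only number in this assay. The other two values sit at the limit (the limit of > 20000 nM in this assay, at which 2 of the 3 values shown sit). For the measured compounds named here, the one step among measured compounds, a step that the two limits leave unreadable from compound 2 to compound 3, is unreadable, so no step bears on the change to compound 4 `Cc1ccccc1-c1nn(Cc2ccc(F)cc2)cc1CNCCN1CCN(C)CC1`, namely (4-fluorobenzyl in place of 4-chlorophenyl on an aromatic nitrogen).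

With no readable step to lean on, no shift beyond the scatter is expected from compound 1 to compound 4 in this assay, giving a 1.2-fold higher number from compound 1 to compound 4 (0.07 log units; within the scatter) as the estimated step. Compound 4 is thus expected near 20000 nM, in the range 10000 nM to 40000 nM, with a fair chance that only a limit is reported.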

Compound 4, half-maximal cytotoxic concentration: > 20000 nM
Compound 4: no number, only a limit; the forecaster's own chance of this, stated with the estimate: 50%; the middle value lies on the limit itself.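

In this assay, compound 4 gives > 20000 nM, a limit of the assay and not a number. On the aromatic nitrogen, 4-fluorobenzyl in place of 4-chlorophenyl gives an at least 1.1-fold higher number from compound 1 to compound 4 (0.07 log units; that floor lies within the scatter), so this change can be read only as a floor and its true size stays hidden. Most of the series now sits at one limit: the limit of > 20000 nM in this assay, at which 3 of the 4 values shown sit.

Open, on these data alone, is whether a 4-chlorobenzyl group on that nitrogen would separate the halogen from the added carbon of the benzyl group. Open too, as far as these compounds go, is whether an unsubstituted benzyl or a 2-phenylethyl group there would give a number rather than a limit.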